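Methyl to Ethyl in a Small Antiproliferative Set

A few compounds are considered here, and "the series" means these few. Any claim that something is new, unique, unknown or untested is made for them only; others in the source may bear on it.

In a functional assay on P388D1 cells (Homo sapiens) for antiproliferative activity, read by sulforhodamine B assay, with a stated time of 48 h (a higher number here means a weaker inhibitor, a lower number a stronger inhibitor), compound 1 (`O=C1NCCN1c1ccc(S(=O)(=O)Nc2ccc3[nH]ccc3c2)cc1`) gives 520 nM, while compound 2 (`Cc1cccc(NS(=O)(=O)c2ccc(N3CCNC3=O)cc2)c1`) gives 250 nM, the lower of the two numbers, with a gap beyond the scatter. Compound 3 (`CCc1cccc(NS(=O)(=O)c2ccc(N3CCNC3=O)cc2)c1`) has methyl in place of hydrogen on a saturated chain carbon bound to an aromatic carbon, which turns 3-methylphenyl into 3-ethylphenyl (methyl in place of hydrogen on a saturated chain carbon bound to an aromatic carbon). Among the compounds with values here, no measured pair shows this change. In this assay no step beyond the scatter is expected in either direction, and the expected step is a 1.0-fold higher number from compound 2 to compound 3 (0.02 log units; within the scatter). The estimated value for compound 3 is 260 nM, within an expected range of 100 nM to 650 nM.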

Compound 3, half-maximal inhibitory concentration: 250 nM
The estimate for compound 3 lay 1.0-fold (0.02 log units) above the measured number, within the range that was stated.
By their numbers in this assay, from the lowest: compounds 2 and 3 (each within the scatter of the next); then compound 1.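

In this assay, replacing 3-methylphenyl with 3-ethylphenyl gives no change at the digits printed from compound 2 to compound 3 (within the scatter), so this place on the saturated chain carbon bound to an aromatic carbon accepts one further carbon without a step beyond the scatter. The earlier compounds shown here offered no pair that isolated this place. Nothing measured on the compounds here accounts for this result.

Going by these compounds, whether a longer chain such as propyl, or an amine or a carboxylic acid, would hold the number at this place remains open. So does whether this single step would carry over to the core of compound 1.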